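Swapping hydroxy for amino on an amide-type nitrogen

A few compounds are considered here, and "the series" means these few. Any claim that something is new, unique, unknown or untested is made for them only; others in the source may bear on it.

Compound 1 `CCOC(=O)c1nc([N+](=O)[O-])cn1Cc1ccc(OC(F)(F)F)cc1` gives > 100000 nM in a toxicity assay on HEK293 cells (Homo sapiens) for inhibition, read by resazurin assay, with a stated time of 24 h (on this read-out higher numbers stand for lower toxicity in this test and lower numbers for higher toxicity in this test), which is a limit of the assay and not a number. Within the data shown here, compound 2 `O=C(NO)c1nc([N+](=O)[O-])cn1Cc1ccc(OC(F)(F)F)cc1` gives 36000 nM, the only true number so far. Among the measured compounds shown here, the single measured step, an at least 2.7-fold lower number from compound 1 to compound 2 (0.44 log units; beyond the scatter), put hydroxyamino in place of ethoxy on a carbonyl carbon. Compound 3 `NNC(=O)c1nc([N+](=O)[O-])cn1Cc1ccc(OC(F)(F)F)cc1` differs from compound 2 by amino in place of hydroxy on an amide-type nitrogen, which is amino in place of hydroxy on an amide-type nitrogen. That swap is smaller than an at least 2.7-fold lower number from compound 1 to compound 2 (0.44 log units; beyond the scatter), so no move beyond the scatter is expected, and the expected step is a 1.4-fold higher number from compound 2 to compound 3 (0.14 log units; within the scatter). For compound 3 the estimated value is 50000 nM, with an expected range from 18000 nM to 100000 nM.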

Compound 3, half-maximal cytotoxic concentration: > 100000 nM
Compound 3 gave a limit, no number (the forecaster's own chance of this, stated with the estimate: 25%); at least 2.0-fold (0.30 log units) between middle value and limit.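

Amino in place of hydroxy on an amide-type nitrogen gives an at least 2.7-fold higher number from compound 2 to compound 3 (0.44 log units; beyond the scatter) in this assay, so this one-atom swap alone moves the read-out beyond the scatter. Of the groups shown on the carbonyl carbon, only hydroxyamino in compound 2 comes off the limit that compound 1 and compound 3 share: the limit of > 100000 nM in this assay, at which 2 of the 3 values shown sit. The step from compound 1 to compound 3 cannot be read, as both values are limits.

Going by these compounds, how far compound 1 and compound 3 lie past that limit stays open. So does whether a methoxy group on the amide-type nitrogen, or a carboxylic acid at the carbonyl carbon, would give a true number.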